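The source may hold more compounds than are shown below. What is called first, only, known or untested is meant among the compounds shown, and "the series" means these compounds.

Compound 1 `C=CC(=O)NCc1coc(-c2c(N)ncnc2Nc2ccc(Oc3ccccc3)c(Cl)c2)n1` gives > 1.66 h in an in vitro ADME assay on microsomes from liver (Homo sapiens) for metabolic stability, tested at 5 uM; a higher number here means that the compound lasts longer, a lower number that the compound disappears faster; this value is a limit of the assay.
Compound 2 `C=CC(=O)NCc1coc(-c2c(N)ncnc2Nc2ccc(F)c(Cl)c2)n1` gives 0.267 h in this assay.

Within the data shown here, compound 2 thus holds the only number among the two values shown; the other is a limit. The unmeasured compound 3 `C=CC(=O)NCc1coc(-c2c(N)ncnc2Nc2ccc(Cl)c(Cl)c2F)n1` differs from compound 2 by 3,4-dichloro-2-fluorophenyl in place of 3-chloro-4-fluorophenyl on a nitrogen on an aromatic ring. Among the measured compounds shown here, the only measured step, an at least 6.2-fold lower number from compound 1 to compound 2 (0.79 log units; beyond the scatter), concerns a different group and a different kind of change, so it does not bear directly on this one. For the measured compounds named here, with no matching measured step, no change beyond the scatter is expected, and the step is estimated as a 1.1-fold higher number from compound 2 to compound 3 (0.05 log units; within the scatter). Compound 3 is therefore expected to give 0.3 h, in the range 0.14 h to 0.7 h.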

Compound 3, half-life: > 1.66 h
Compound 3: no number, only a limit; the forecaster's own chance of this, stated with the estimate: 5%; middle value at least 5.5-fold (0.74 log units) away from the limit.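

The change from 3-chloro-4-fluorophenyl to 3,4-dichloro-2-fluorophenyl on a nitrogen on an aromatic ring brings an at least 6.2-fold higher number from compound 2 to compound 3 (0.79 log units; beyond the scatter) in this assay. The earlier step concerned only the loss of phenoxy, whereas this one shows that the group on this nitrogen can also shift the half-life beyond the scatter, with no phenoxy present. The value of compound 3 is a limit, not a number, so the true size of the step stays unknown: the limit of > 1.66 h in this assay, at which 2 of the 3 values shown sit.

The compounds shown leave open whether the second chlorine or the shifted fluorine carries the step, and how compound 1 and compound 3 compare. They also do not show how a methoxy group or an amine on this ring would fare.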